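Stripping the Benzyl Group Down to a Bare Amine

The source may report more compounds than this note shows. Statements on the series, on what has been measured and on what is new or still open speak of the compounds shown alone.

Compound 1 `CCCCC#Cc1nc(NCc2cccc(Br)c2)c2ncn([C@H]3[C@H](O)[C@H](O)[C@@H]4C[C@@H]43)c2n1` was tested in an assay on CHO cells for displacement of a labelled ligand from adenosine receptor A1 (Homo sapiens), read by scintillation counting, with a stated time of 60 min, tested at 10 uM (a higher number here means more inhibition at the concentration tested (going by the name of the read-out), a lower number less inhibition), where compound 1 gives 38%. Among the three measured compounds this places compound 1 second highest. Compound 2 `CCCCC#Cc1nc(NCc2cccc(I)c2)c2ncn([C@H]3[C@H](O)[C@H](O)[C@@H]4C[C@@H]43)c2n1` gives 48% in this assay, and a number 10 percentage points higher from compound 1 to compound 2 (within the scatter). Compound 3 `CCCCC#Cc1nc(NCC)c2ncn([C@H]3[C@H](O)[C@H](O)[C@@H]4C[C@@H]43)c2n1` gives 31%, and a number 7 percentage points lower from compound 1 to compound 3 (within the scatter). Between the other two, a number 17 percentage points lower from compound 2 to compound 3 (beyond the scatter).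

Compound 4 `CCCCC#Cc1nc(N)c2ncn([C@H]3[C@H](O)[C@H](O)[C@@H]4C[C@@H]43)c2n1` differs from compound 1 by hydrogen in place of 3-bromobenzyl on a nitrogen on an aromatic ring. For the measured compounds named here, no measured step removes the whole group; the nearest guide is the step from compound 1 to compound 3, which trims the 3-bromophenyl to methyl and stays within the scatter, and the step from compound 2 to compound 3, which is modest but beyond the scatter. Both point the same way, downward, when the aromatic part is removed. Taking the group off entirely is a larger change than either measured step, so a further fall in this assay is expected, though the two measured steps leave its size uncertain. Compound 4 is therefore estimated at 25%, in a range from 8% to 42%, which would mean an expected step of a number 13 percentage points lower from compound 1 to compound 4 (beyond the scatter).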

Compound 4, a percentage reported as inhibition, at one concentration (the size of the read-out at that concentration, not a potency): 29%
Beside the measured number, compound 4's estimate is 4 percentage points below it; the measured number falls inside the stated range.
By their numbers in this assay, from the lowest: compounds 4, 3, 1 and 2 (each within the scatter of the next, the first and the last beyond it).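

Replacing the 3-bromobenzyl group on this nitrogen with hydrogen, which turns (3-bromobenzyl)amino into amino, gives a number 9 percentage points lower from compound 1 to compound 4 (within the scatter) in this assay, and replacing the ethyl group of compound 3 gives a number 2 percentage points lower from compound 3 to compound 4 (within the scatter), so the bare amine cannot be told apart from either of these substituted amines in this test at a single concentration. For the compounds shown here, only the 3-iodobenzyl group separates from the bare amine, with a number 19 percentage points lower from compound 2 to compound 4 (beyond the scatter), a modest step that makes compound 2 the one compound here whose number stands clear of compound 4, while the whole aromatic ring can leave compound 1 without a step beyond the scatter. Nothing on hand explains why these steps have the sizes they do.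

Still open, on these data alone, is whether the step seen with iodo depends on that halogen, which a chloro or a methoxy group in place of the bromo on the benzyl ring could help to test. As far as these compounds go, it is also open how a longer chain such as hexyl, or a cyclopentyl group, in place of the ethyl on this nitrogen would read in this assay when set against the bare amine.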